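The source may report more compounds than this note shows. Statements on the series, on what has been measured and on what is new or still open speak of the compounds shown alone.

In a functional assay on PC-3 cells (Homo sapiens) for antiproliferative activity, read by CCK-8 assay, with a stated time of 6 days (on this read-out lower numbers stand for stronger inhibition and higher numbers for weaker inhibition), compound 1 `CCN(c1cccc(-n2ccnc2)c1)c1ccc(C#N)c(C(F)(F)F)c1`, which also carries a trifluoromethyl, gives > 30000 nM, a limit and not a number. Compound 2 `CCN(c1ccc(C#N)c(Cl)c1)c1cc(-n2ccnc2)ccc1C` gives > 30000 nM, again only a limit. Compound 3 `CCN(c1ccc(C#N)c(C(F)(F)F)c1)c1cc(-n2ccnc2)ccc1C` has trifluoromethyl in place of chloro on an aromatic carbon, ortho to a cyano group (trifluoromethyl in place of chloro on an aromatic carbon). This expectation rests on (the limit of > 30000 nM in this assay, at which 2 of the 2 values shown sit). In this assay, the estimated a number no higher from compound 2 to compound 3 (the limit leaves the size open) is expected to stay within the usual scatter, in neither direction. Compound 3 is expected to give 30000 nM, with an estimated range of 10000 nM to 60000 nM.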

Compound 3, half-maximal inhibitory concentration: > 30000 nM
Compound 3: only a limit was reported (the forecaster's own chance of this, stated with the estimate: 80%); the middle value lies on the limit itself.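

In this assay compound 3 gives > 30000 nM, a limit and not a number. For the compounds shown here, no step from compound 1 or compound 2 to compound 3 can be read, as all three stand only at limits. The compounds shown leave open what trifluoromethyl in place of chloro, or methyl in place of hydrogen, does in this assay.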